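The source may report more compounds than this note shows. Statements on the series, on what has been measured and on what is new or still open speak of the compounds shown alone.

Of the compounds shown here, three built on one shared core have been tested in a functional assay on HL-60 cells (Homo sapiens) for cytotoxicity, read by MTT assay, with a stated time of 48 h; a higher number here means a weaker inhibitor, a lower number a stronger inhibitor. Compound 1 `Fc1ccc2nc(-c3ccccc3)nc(Nc3ccccc3)c2c1` carries a plain phenylamino group. In this assay compound 1 gives > 50000 nM, which is a limit of the assay rather than a number. Compound 2 `Fc1cccc(-c2nc(Nc3ccccc3F)c3cc(F)ccc3n2)c1` has the same core with a 2-fluorophenyl on the nitrogen. In this assay compound 2 gives > 50000 nM, again only a limit. Compound 3 `Fc1cccc(-c2nc(Nc3cccc(Cl)c3)c3cc(F)ccc3n2)c1` replaces that group with a 3-chlorophenyl. In this assay compound 3 gives > 50000 nM, once more a limit. Within the data shown here, the only single-change step among them, a step that the two limits leave unreadable from compound 2 to compound 3, therefore has no readable size; every value shown rests at the limit of > 50000 nM in this assay, at which 3 of the 3 values shown sit, so no direction of change can be told.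

Compound 4 `Nc1cccc(Nc2nc(-c3cccc(F)c3)nc3ccc(F)cc23)c1` is the next member and is yet unmeasured. It differs from compound 3 as follows: amino in place of chloro on an aromatic carbon. Among the measured compounds shown here, no measured step speaks to this amino for chloro exchange, and the three limits give no slope to follow. The step from compound 3 to compound 4 is therefore expected to be a number no higher from compound 3 to compound 4 (the limit leaves the size open), with compound 4 most likely to return another limit. For compound 4 in this assay the estimate is 50000 nM, with a range from 10000 nM to 200000 nM.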

Compound 4, half-maximal inhibitory concentration: > 50000 nM
Compound 4: a limit, no number; the forecaster's own chance of this, stated with the estimate: 80%; the middle value sits exactly at the limit.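

Compound 4 returns only a limit, so neither the step to it from compound 2 nor the step to it from compound 3 can be read: the limit of > 50000 nM in this assay, at which 4 of the 4 values shown sit. The compounds shown leave open whether any change on the shared core would give a measurable number in this assay, and which group would do so.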